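Swapping Isopropyl for Allyl in Compound 3

The source may report more compounds than this note shows. Statements on the series, on what has been measured and on what is new or still open speak of the compounds shown alone.

In a functional assay on the whole organism (strain Sprague-Dawley) for inhibition, with Rattus norvegicus as the target, with a stated time of 10 min (on this read-out higher numbers stand for an effect only at larger amounts of compound and lower numbers for an effect already at smaller amounts), compound 1 `C=CCOc1ccccc1-c1ncc(C(=O)O)c(=O)[nH]1` gives 0.5 mg/kg as its dose. Compound 2 `CCOC(=O)c1cnc(-c2ccccc2N)[nH]c1=O` stands as "not determined" (no result reported) and offers no comparison. Compound 3 `CCOC(=O)c1cnc(-c2ccccc2OC(C)C)[nH]c1=O` gives 2 mg/kg and so holds the higher of the two numbers, a gap to compound 1 that lies beyond the scatter. Compound 4 `C=CCOc1ccccc1-c1ncc(C(=O)OCC)c(=O)[nH]1` differs from compound 3 in one place: allyl in place of isopropyl on an oxygen on an aromatic ring with allyl in place of isopropyl on an oxygen on an aromatic ring. Among the compounds with values here, no measured pair shows this swap alone. Compound 1 also carries allyl, but with 0.5 mg/kg it is only a loose guide, since it differs from compound 4 elsewhere too. No step beyond the scatter is expected, and the estimated change is a 1.3-fold lower number from compound 3 to compound 4 (0.12 log units; within the scatter) at most modest. Compound 4 is expected at 1.5 mg/kg in this assay (0.5 mg/kg to 4 mg/kg).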

Compound 4, dose for 50% inhibition: 0.5 mg/kg
Estimate against measurement, compound 4: 3.0-fold (0.48 log units) above; the measured number falls inside the stated range.
By their numbers in this assay, from the lowest: compounds 1 and 4 (each within the scatter of the next); then compound 3.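

Replacing isopropoxy with allyloxy on the aromatic ring gives a 4.0-fold lower number from compound 3 to compound 4 (0.60 log units; beyond the scatter) in this assay, so this position responds to a change between two groups that each hold 3 carbon atoms. With allyloxy in place, ethyl in place of hydrogen on an oxygen next to a carbonyl group gives no change at the digits printed from compound 1 to compound 4 (within the scatter), so the ester and the acid cannot be told apart here. Nothing available gives a reason for either result. As far as these compounds go, whether a longer chain such as butoxy or a benzyloxy group on that ring would go further remains open.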